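A larger sugar-like ring on the aromatic nitrogen

A few compounds are considered here, and "the series" means these few. Any claim that something is new, unique, unknown or untested is made for them only; others in the source may bear on it.

Compound 1 `O=C1c2c[n+]([O-])c3ccccc3c2C(=O)c2c1c1ccccc1n2Cc1cn(C[C@@H](O)CO)nn1` gives only a limit in a functional assay on SH-SY5Y cells (Homo sapiens) for cytotoxicity, read by MTT assay, with a stated time of 72 h (on this read-out higher numbers stand for weaker inhibition and lower numbers for stronger inhibition), namely > 500 nM, which is a limit of the assay and not a number. Compound 2 `CC1(C)OCC(Cn2cc(Cn3c4c(c5ccccc53)C(=O)c3c[n+]([O-])c5ccccc5c3C4=O)nn2)O1` gives 230 nM in this assay. Compound 3 `O=C1c2c[n+]([O-])c3ccccc3c2C(=O)c2c1c1ccccc1n2Cc1cn([C@@H]2C[C@H](O)[C@@H](CO)O2)nn1` gives 150 nM in this assay.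

Compound 3 has the lowest of the two numbers given, but its gap to compound 2, a 1.5-fold lower number from compound 2 to compound 3 (0.19 log units; within the scatter), is within the scatter, so the two cannot be ranked. Compound 4 `O=C1c2c[n+]([O-])c3ccccc3c2C(=O)c2c1c1ccccc1n2Cc1cn([C@@H]2O[C@H](CO)[C@@H](O)[C@H](O)[C@H]2O)nn1` differs from compound 3 by 3,4,5-trihydroxy-6-(hydroxymethyl)oxan-2-yl in place of 4-hydroxy-5-(hydroxymethyl)oxolan-2-yl on an aromatic nitrogen. Among the compounds with values here, the steps that bear on this change the group on that same aromatic nitrogen: an at least 3.3-fold lower number from compound 1 to compound 3 (0.52 log units; beyond the scatter) and a 1.5-fold lower number from compound 2 to compound 3 (0.19 log units; within the scatter), both ending at compound 3, while compound 1 carries many hydroxyls and sits only at a limit (the limit of > 500 nM in this assay, at which 1 of the 3 values shown sits). The entering 3,4,5-trihydroxy-6-(hydroxymethyl)oxan-2-yl also carries many hydroxyls, so a modest rise in number is expected, a 2.0-fold higher number from compound 3 to compound 4 (0.30 log units; within the scatter). For compound 4 the estimate in this assay is 300 nM, between 120 nM and 900 nM.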

Compound 4, half-maximal inhibitory concentration: 880 nM
Beside the measured number, compound 4's estimate is 2.9-fold (0.47 log units) below it; low and high end bracket the measured number.
By their numbers in this assay, from the lowest: compounds 3 and 2 (each within the scatter of the next); then compound 4.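

In this assay, the six-membered 3,4,5-trihydroxy-6-(hydroxymethyl)oxan-2-yl on the aromatic nitrogen gives a 5.9-fold higher number from compound 3 to compound 4 (0.77 log units; beyond the scatter), the first readable rise beyond the scatter at this position. The same group also gives a 3.8-fold higher number from compound 2 to compound 4 (0.58 log units; beyond the scatter), so compound 4 sits apart from both compound 2 and compound 3, which cannot be ranked against each other. Compound 1 has only a limit, and its step to compound 4 cannot be read: the limit of > 500 nM in this assay, at which 1 of the 4 values shown sits.

The compounds shown change ring size and hydroxyl count together and do not separate the two. On these data alone, how an amine or a carboxylic acid on this nitrogen would read remains open.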